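The compounds below may be only part of what the source reports. "The series", "measured", "known", "first", "only" and "open" are said of these compounds alone.

Measured compounds:
compound 1 `Nc1nc(Cl)c2ncn(Cc3ccc(CCl)cc3)c2n1`, 3390 nM
compound 2 `ClCc1cccc(Cn2cnc3c(Cl)nc(Cl)nc32)c1`, 1580 nM
compound 3 `ClCc1ccc(Cn2cnc3c(Cl)nc(Cl)nc32)cc1`, 3800 nM

Of the compounds shown here, three have been measured in a functional assay on SW-620 cells (Homo sapiens) for cytotoxicity, read by sulforhodamine B assay, with a stated time of 48 h; on this read-out lower numbers stand for stronger inhibition of growth and higher numbers for weaker inhibition of growth. Compound 1 gives 3390 nM, compound 3 gives 3800 nM, and compound 2 gives 1580 nM, which is the lowest of the three numbers, with its step to each of the other two beyond the usual scatter. The values of compound 1 and compound 3 lie within the scatter of each other, so no order between them is claimed.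

Compound 3 and compound 1 differ in one place: amino in place of chloro on an aromatic carbon. That change made a 1.1-fold lower number from compound 3 to compound 1 (0.05 log units; within the scatter). The cores of compound 2 and compound 3 are built from the same atoms joined differently; the difference between the two cores is not broken down here.

Compound 4 `Nc1nc(Cl)c2ncn(Cc3cccc(CCl)c3)c2n1` has not yet been measured in this assay. It stands to compound 2 as compound 1 stands to compound 3, and the change is the same: amino in place of chloro on an aromatic carbon. Because the earlier instance of this change made a 1.1-fold lower number from compound 3 to compound 1 (0.05 log units; within the scatter), the expected step from compound 2 to compound 4 is likewise small, a 1.0-fold higher number from compound 2 to compound 4 (0.01 log units; within the scatter). Among the compounds with values here, compound 4 is therefore expected to give about 1600 nM in this assay, with the estimate resting on the single measured instance of the change and spanning from 700 nM to 3600 nM.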

Compound 4, concentration for 50% growth inhibition: 3800 nM
For compound 4 the middle estimate is 2.4-fold (0.38 log units) below the measured one, outside the stated range (above it).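

Amino in place of chloro on an aromatic carbon gave a 2.4-fold higher number from compound 2 to compound 4 (0.38 log units; beyond the scatter) in this assay, and the same change did not behave alike on the two cores: the same change on two cores in this assay, a 1.1-fold lower number (0.05 log units; within the scatter) from compound 3 to compound 1 and a 2.4-fold higher number (0.38 log units; beyond the scatter) from compound 2 to compound 4, 2.7-fold (0.43 log units) apart, beyond the scatter of two such steps

In this series, then, the size of the step on the core of compound 3 was no guide to its size on the core of compound 2, and a step read on one of these cores cannot simply be moved to the other. Within the data shown here, with only one pair on each core, the result shows that the two steps differ, but it does not show why they differ or how the change would behave on any further core.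

The compounds shown hold only chloro or amino on that aromatic carbon, which leaves open how a methoxy group or a dimethylamino group there would read in this assay. From the compounds shown here alone, all four also carry a chloromethyl group, and how a hydroxymethyl group or a plain methyl group in its place would read, on either core, stays open as well.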